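Lengthening the Side Chain on a Cyclic Phosphate Nucleoside

The compounds below may be only part of what the source reports. "The series", "measured", "known", "first", "only" and "open" are said of these compounds alone.

Compound 1 `CCc1cn([C@H]2C[C@@H]3OP(=O)(O)OC[C@H]3O2)c(=O)[nH]c1=O` carries an ethyl group on its base and a cyclic phosphate bridging the sugar. Among the compounds with values here, in a functional assay on L1210 cells (Mus musculus) (a higher number here means a weaker inhibitor, a lower number a stronger inhibitor), compound 1 gives 55 ug/mL, the lower of the two numbers measured so far. Compound 2 `CCCCCc1cn([C@H]2C[C@H](O)[C@@H](CO)O2)c(=O)[nH]c1=O` carries a pentyl chain and an open sugar without the phosphate bridge; in this assay compound 2 gives 476 ug/mL, and its gap to compound 1 lies beyond the usual scatter, so compound 1 is the stronger inhibitor of the pair. Compound 3 `CCCCCc1cn([C@H]2C[C@@H]3OP(=O)(O)OC[C@H]3O2)c(=O)[nH]c1=O` keeps the cyclic phosphate of compound 1 and changes only the side chain: propyl in place of hydrogen on a saturated chain carbon, two bonds along the chain from an aromatic carbon. Within the data shown here, no two measured compounds differ in that single place, so the step itself is unknown. The step of a 2.9-fold higher number from compound 1 to compound 3 (0.46 log units; beyond the scatter) is expected to weaken inhibition beyond the scatter, because compound 2 with the same pentyl chain gives 476 ug/mL. For compound 3 the estimate is 160 ug/mL, in a range from 40 ug/mL to 600 ug/mL.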

Compound 3, concentration for 50% inhibition: > 500 ug/mL
Compound 3: a limit, no number (the forecaster's own chance of this, stated with the estimate: 5%); middle value at least 3.1-fold (0.49 log units) away from the limit.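

With the cyclic phosphate held fixed, the change from ethyl to pentyl can now be read on its own: in this assay it gives an at least 9.0-fold higher number from compound 1 to compound 3 (0.95 log units; beyond the scatter). The earlier compounds shown here differed in both the chain and the sugar, whereas this pair shows that the added propyl alone, on a saturated chain carbon, two bonds along the chain from an aromatic carbon, is enough to weaken inhibition beyond the scatter. Compound 3 stands at > 500 ug/mL, which is a limit of the assay and not a number, so the full size of the step stays unknown: the limit of > 500 ug/mL in this assay, at which 1 of the 3 values shown sits.

The compounds shown do not tell why the pentyl chain weakens inhibition. From the compounds shown here alone, it also remains open how a propyl or butyl chain would behave here, or a chain ending in an amine.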